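Swapping a furan for a chlorophenyl on a hydrazone arm

The source may report more compounds than this note shows. Statements on the series, on what has been measured and on what is new or still open speak of the compounds shown alone.

Measured so far:
- compound 1, `Cn1c(=O)c(=O)n(C2CCCC2)c2nc(N/N=C/c3ccco3)ncc21`, 72200 nM
- compound 2, `COc1cc(/C=N/Nc2ncc3c(n2)n(C2CCCC2)c(=O)c(=O)n3C)cc(OC)c1OC`, 17500 nM

Two compounds share one core and differ only in the aromatic group hanging from the hydrazone arm. In a functional assay on PC-3 cells (Homo sapiens) for antiproliferative activity, read by MTT assay (a lower number here means a stronger inhibitor, a higher number a weaker inhibitor), compound 1 gives 72200 nM, the higher of the two numbers, so it is the weaker of the pair. Compound 2, carrying a trimethoxyphenyl group, gives 17500 nM in this assay, a gap that lies beyond the usual scatter.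

Compound 3, `Cn1c(=O)c(=O)n(C2CCCC2)c2nc(N/N=C/c3ccccc3Cl)ncc21`, has not yet been measured. It differs from compound 1 in one place: 2-chlorophenyl in place of furan-2-yl on a carbon with a double bond to nitrogen. Going by the values given here, no measured pair shows this exact exchange, so the size of the step can only be guessed from the two numbers at hand. Among the compounds with values here, since the one change of aryl group seen so far, from compound 1 to compound 2, lowered the number, a moderate move in the same direction is expected from compound 1 to compound 3 in this assay, of roughly a 2.4-fold lower number from compound 1 to compound 3 (0.38 log units; beyond the scatter). Compound 3 is therefore estimated at 30000 nM, with a plausible range from 10000 nM to 90000 nM.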

Compound 3, half-maximal inhibitory concentration: 16300 nM
For compound 3 the middle estimate is 1.8-fold (0.26 log units) above the measured one, within the range that was stated.
By their numbers in this assay, from the lowest: compounds 3 and 2 (each within the scatter of the next); then compound 1.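

In this assay, putting 2-chlorophenyl in place of furan-2-yl on a carbon with a double bond to nitrogen gives a 4.4-fold lower number from compound 1 to compound 3 (0.65 log units; beyond the scatter), so this single exchange on the hydrazone arm is enough to move the number beyond the scatter. This adds a second aryl group to the comparison with the furan-2-yl of compound 1: compound 3 gives 16300 nM and compound 2 gives 17500 nM, values within the scatter of each other, so the two different six-membered aromatic rings cannot be ranked in this assay. No measurement at hand explains the shift or says which feature of the 2-chlorophenyl group lies behind it.

The compounds shown leave open whether the chlorine matters at all, since a plain phenyl group on this same carbon would be needed to separate the effect of the ring from that of its chlorine. They also leave open how this position would respond to a pyridine ring, or to a phenyl ring carrying an amine or a carboxylic acid.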